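This account rests on a few compounds, and the source may have more. Where it says the series, first, only, none or still open, it means among the compounds named here.

Compound 2 `Cc1ccc(C(=O)OC2(C(=O)Nc3ccc([N+](=O)[O-])cc3)CCCCC2)cc1` gives 45.4 nM in a functional assay on NFS-60 cells (Mus musculus) for inhibition, read by MTT assay, with a stated time of 72 h; on this read-out higher numbers stand for weaker inhibition and lower numbers for stronger inhibition. Going by the values given here, compound 1 `O=C(OC1(C(=O)Nc2ccc([N+](=O)[O-])cc2)CCCCC1)c1ccc(C(F)(F)F)cc1` gives 26 nM in this assay, and this is the only other number, so compound 2 stands with it, since a 1.7-fold higher number from compound 1 to compound 2 (0.24 log units; within the scatter). Compound 3 `O=C(OC1(C(=O)Nc2ccc([N+](=O)[O-])cc2)CCCCC1)c1ccc(Cl)cc1` differs from compound 2 by chloro in place of methyl on an aromatic carbon. Among the compounds with values here, the one step that bears on this exchange, a 1.7-fold higher number from compound 1 to compound 2 (0.24 log units; within the scatter), also replaced the group on an aromatic carbon and stayed within the scatter, so no step beyond the scatter is expected here either. Compound 3 is therefore expected at 35 nM, with a range of 12 nM to 110 nM, an expected step of a 1.3-fold lower number from compound 2 to compound 3 (0.11 log units; within the scatter).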

Compound 3, half-maximal inhibitory concentration: 10.3 nM
Compound 3: the middle estimate sits 3.4-fold (0.53 log units) above what was measured; measured number below the stated range.
By their numbers in this assay, from the lowest: compound 3; then compounds 1 and 2 (each within the scatter of the next).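

In this assay this position turns out to respond to the group it carries: chloro in place of methyl gives a 4.4-fold lower number from compound 2 to compound 3 (0.64 log units; beyond the scatter) and chloro in place of trifluoromethyl gives a 2.5-fold lower number from compound 1 to compound 3 (0.40 log units; beyond the scatter) while the exchange of the earlier two groups stayed within the scatter. Chloro therefore stands apart from both methyl and trifluoromethyl here, which the earlier compounds could not show. Nothing available here explains this difference. The compounds shown leave open whether bromo or fluoro at this place would match chloro, and what an amine or a methoxy group would do there.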